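The source may hold more compounds than are shown below. What is called first, only, known or untested is meant among the compounds shown, and "the series" means these compounds.

Of the compounds shown here, three built on a shared core have so far been tested in a functional assay on HCT-116 cells (Homo sapiens) for cytotoxicity, read by MTT assay, with a stated time of 72 h; a higher number here means a weaker inhibitor, a lower number a stronger inhibitor. Compound 1 `NCCCNc1c(C(=O)NCc2ccc(F)cc2)ncc2cccnc12` reached only the edge of what the assay can report: in this assay compound 1 gives > 10000 nM, a limit and not a number. Compound 3 `N[C@H]1CC[C@H](Nc2c(C(=O)NCc3ccc(F)cc3)nc(N3CCCCS3(=O)=O)c3cccnc23)CC1` stands the same way, since in this assay compound 3 gives > 10000 nM, again a limit. Compound 2 `O=C(NCCCNc1c(C(=O)NCc2ccc(F)cc2)nc(Br)c2cccnc12)c1ccccc1` is no different on the numbers shown; in this assay compound 2 gives > 10000 nM, which is likewise a limit rather than a measured value. All three therefore sit at the limit of > 10000 nM in this assay, at which 3 of the 3 values shown sit, and no step between measured compounds can be drawn, so nothing on the numbers shown sets compound 2 apart from the other two.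

The account now follows compound 2 to compound 4 `CNc1c(C(=O)NCc2ccc(F)cc2)nc(Br)c2cccnc12`. The change from one to the other is hydrogen in place of 2-benzamidoethyl on a saturated chain carbon bound to a nitrogen on an aromatic ring. Within the data shown here, with every measured compound at the limit, the data give no measured step to lean on, and the expectation for compound 4 can rest only on the observation that compound 1, carrying a small group at the same kind of position, also gives > 10000 nM. The step that the limit leaves unreadable from compound 2 to compound 4 is therefore expected to be none beyond the scatter, with no direction to it. For compound 4 in this assay the estimate is 20000 nM, ranging from 5000 nM to 100000 nM, and it is expected that the assay will most likely once more return only a limit.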

Compound 4, half-maximal inhibitory concentration: > 20000 nM
Compound 4 gave a limit, no number; the forecaster's own chance of this, stated with the estimate: 80%; the middle value lies on the limit itself.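

In this assay compound 4 gives > 20000 nM, which is a limit and not a number. Compound 2 gives > 10000 nM, also a limit, so no step can be read between compound 2 and compound 4. The compounds shown leave open whether hydrogen in place of 2-benzamidoethyl changes anything in this assay, and what number any of the four compounds would reach.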